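The compounds below may be only part of what the source reports. "The series", "measured", "known", "first", "only" and "open" are said of these compounds alone.

Compound 1, `CCOC(=O)C1CCCCN1S(=O)(=O)c1ccc(S(=O)(=O)N(CC)CC)cc1`, carries a cyclic amino acid ester on one sulfonyl group and a diethylamino group on the other. In a functional assay on MIA PaCa-2 cells (Homo sapiens) for inhibition, read by MTT assay, with a stated time of 7 days (a higher number here means a weaker inhibitor, a lower number a stronger inhibitor), compound 1 gives 24600 nM. Compound 2, `CCOC(=O)[C@@H]1CCCN(S(=O)(=O)c2ccc(S(=O)(=O)N(C)Cc3ccccc3)cc2)C1`, keeps a closely related core but bears a benzyl(methyl)amino group on the second sulfonyl sulfur. In this assay compound 2 reaches only a limit, > 30000 nM, so no number is known for it. The account therefore rests on the limit of > 30000 nM in this assay, at which 1 of the 2 values shown sits, for compound 2 and on the measured value of compound 1.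

Compound 3, `CCCN(CC)S(=O)(=O)c1ccc(S(=O)(=O)N2CCC[C@@H](C(=O)OCC)C2)cc1`, is compound 2 with one change: ethyl(propyl)amino in place of benzyl(methyl)amino on a sulfonyl sulfur. The group that enters resembles the diethylamino group of compound 1 in being a small, ring-free dialkylamino substituent. Because compound 1 gives 24600 nM, compound 3 is expected to fall near that weak level, and the expected step of an at least 1.2-fold lower number from compound 2 to compound 3 (0.07 log units; that floor lies within the scatter) is judged to be small, within the scatter, or at most a modest move toward a stronger inhibitor. In this assay compound 3 is therefore estimated at 25000 nM, with a plausible range from 10000 nM to 60000 nM.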

Compound 3, half-maximal inhibitory concentration: 300 nM
Compound 3: middle estimate off by 83-fold (1.92 log units), on the high side, and the stated range ends above it.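

On a sulfonyl sulfur whose other neighbours are aromatic carbon, exchanging benzyl(methyl)amino for ethyl(propyl)amino gives an at least 100-fold lower number from compound 2 to compound 3 (2.00 log units; beyond the scatter) in this assay. Compound 1 and compound 2 differ in more than one place, so they could not show what this substituent does alone; this pair shows that a change at this one place, with the rest of the shared core held fixed, can move the read-out by a large margin. The step is only a floor, because compound 2 has no numerical value at this end of the comparison, and its true distance from compound 3 remains unknown: the limit of > 30000 nM in this assay, at which 1 of the 3 values shown sits.

From the compounds shown here alone, a single pair cannot separate the loss of the six-membered aromatic ring of benzyl(methyl)amino from the effect of the ethyl and propyl chains themselves, and that question stays open. Also open, going by these compounds, is how the read-out would respond to a longer chain such as dibutylamino on the same sulfonyl sulfur, to a cyclic amine such as piperidine there, or to a carboxylic acid in place of the ethyl ester.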